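The source may report more compounds than this note shows. Statements on the series, on what has been measured and on what is new or still open speak of the compounds shown alone.

Measured so far in an ADME assay on A549 cells (Homo sapiens) for cytotoxicity, read by CellTiter-Glo; on this read-out lower numbers stand for higher toxicity in this test and higher numbers for lower toxicity in this test:
Compound 1 `Cc1c(Cc2ccc(Br)cc2)c(=O)oc2cc(OCC(O)CN3CCC(C(N)=O)CC3)ccc12` — compound 1 gives > 100000 nM, a limit of the assay.
Compound 2 `Cc1c(Cc2ccc(F)cc2F)c(=O)oc2cc(OCC(O)CN3CCC(C(N)=O)CC3)ccc12` — compound 2 gives > 100000 nM, again a limit of the assay.

Compound 2 therefore stands only at the limit, with no number read for it. Among the compounds with values here, the one measured step, a step that the two limits leave unreadable from compound 1 to compound 2, cannot be sized, both values sitting at the limit of > 100000 nM in this assay, at which 2 of the 2 values shown sit. Compound 3 `Cc1c(Cc2ccc(F)cc2Cl)c(=O)oc2cc(OCC(O)CN3CCC(C(N)=O)CC3)ccc12` differs from compound 2 by chloro in place of fluoro on an aromatic carbon. That step gives no readable size for a halogen exchange on this benzyl group, so no movement beyond the scatter is expected in this assay. Compound 3 is expected to remain at the limit, estimated at 150000 nM (range 40000 nM to 1000000 nM). The expected step is a step that the limit leaves unreadable from compound 2 to compound 3.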

Compound 3, half-maximal cytotoxic concentration: 90800 nM
Compound 3: middle estimate off by 1.7-fold (0.22 log units), on the high side, within the range that was stated.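

In this assay, within the data shown here, compound 3 is the first compound of the series to give a number rather than a limit. Chloro in place of fluoro on this aromatic carbon gives an at least 1.1-fold lower number from compound 2 to compound 3 (0.04 log units; that floor lies within the scatter), and 2-chloro-4-fluorophenyl in place of 4-bromophenyl gives an at least 1.1-fold lower number from compound 1 to compound 3 (0.04 log units; that floor lies within the scatter). Both steps are floors only, so neither change is shown to move the number beyond the scatter, and the step between the two earlier compounds remains unreadable.

Still open, going by these compounds, is whether a trifluoromethyl or methoxy group on this same aromatic carbon would leave the number at the limit or bring it clearly lower.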